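Adding a Methoxy Group to Compound 3

This account rests on a few compounds, and the source may have more. Where it says the series, first, only, none or still open, it means among the compounds named here.

Of the compounds shown here, three built on one shared core have been measured in a functional assay on LOX IMVI cells (Homo sapiens) for inhibition, read by sulforhodamine B assay, with a stated time of 48 h, tested at 10 uM; a higher number here means more inhibition of growth at the concentration tested, a lower number less inhibition of growth. Compound 1 (`COc1ccc(-c2nc3sc(-c4ccccc4)cn3n2)cc1`) gives 45%, and compound 2 (`COc1cc(-c2nc3sc(-c4ccccc4)cn3n2)cc(OC)c1OC`) gives 33%. Compound 3 (`Clc1ccc(-c2cn3nc(-c4ccccc4)nc3s2)cc1`) gives 19%, the lowest of the three numbers and beyond the scatter of both others.

Compound 4 (`COc1ccc(-c2nc3sc(-c4ccc(Cl)cc4)cn3n2)cc1`) follows from compound 3 with methoxy in place of hydrogen on an aromatic carbon, para to a large group: methoxy in place of hydrogen on an aromatic carbon. Among the compounds with values here, no two measured compounds differ in only one place, so the size of this change has not been observed directly. The guidance is indirect and rests on very few numbers. Compound 1 also carries a methoxy group and gives 45%, while compound 2, with methoxy groups of its own, gives 33%. Both numbers are higher than that of compound 3, which has no methoxy group and gives 19%. A moderate rise in this assay is therefore expected, although it may only just clear the scatter. The expected change is a number 19 percentage points higher from compound 3 to compound 4 (beyond the scatter). For compound 4 the estimated value is 38%, with an expected range of 18% to 60%.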

Compound 4, percent growth inhibition at one concentration: 45.8%
Estimate against measurement, compound 4: 7.8 percentage points below; the range from low to high includes it.
By their numbers in this assay, from the lowest: compound 3; then compound 2; then compounds 1 and 4 (each within the scatter of the next).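

In this assay, within the data shown here, the methoxy group on an aromatic carbon, para to a large group, can now be read directly: methoxy in place of hydrogen gives a number 26.8 percentage points higher from compound 3 to compound 4 (beyond the scatter) and supplies one of the first comparisons in this set between compounds that differ in only one place. The second comparison reads differently, as chloro in place of hydrogen on an aromatic carbon gives a number 0.8 percentage points higher from compound 1 to compound 4 (within the scatter) and leaves no readable mark on growth inhibition in a compound that already carries the methoxy group. Nothing available here offers an explanation for either step.

Going by these compounds, these two steps rest on a single pair each, so it remains open whether the methoxy step would have a similar size on a compound without the chloro group, or whether it depends on that group being present. On these data alone, it is also open how an ethoxy group, an amine or a carboxylic acid would compare with methoxy at this same place, and so whether the step is particular to methoxy or is shared by other groups.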